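A few compounds are considered here, and "the series" means these few. Any claim that something is new, unique, unknown or untested is made for them only; others in the source may bear on it.

Compound 1, `O=C(/C=C/c1ccc([N+](=O)[O-])cc1)c1ccc(O)c(O)c1`: in a functional assay on HCT-116 cells (Homo sapiens) for cytotoxicity, read by resazurin assay, with a stated time of 48 h (on this read-out higher numbers stand for an effect only at larger amounts of compound and lower numbers for an effect already at smaller amounts), compound 1 gives 5800 nM.
Compound 2, `O=C(/C=C/c1ccccc1)c1ccc(NC(=O)c2ccccc2)cc1`: in this assay compound 2 gives 17000 nM.
Compound 3, `CC(=O)Nc1ccc(C(=O)/C=C/c2cccc([N+](=O)[O-])c2)cc1`: in this assay compound 3 gives 1700 nM.

Among these three, compound 3 has the lowest number: compound 1 lies above it beyond the scatter, and compound 2 lies further above it still. Compound 4, `O=C(/C=C/c1cccc([N+](=O)[O-])c1)c1ccc(NC(=O)c2ccco2)cc1`, is not yet measured. It differs from compound 3 in one place: furan-2-yl in place of methyl on a carbonyl carbon. Among the measured compounds shown here, no measured pair shows this change alone, so the size of its effect on the numbers is unknown. Compound 2, which carries a larger group on the amide-type nitrogen than compound 3 but lacks the nitro group, gives a higher number, but two changes separate it from compound 3. A modest step, within or near the scatter, is expected for a 1.5-fold higher number from compound 3 to compound 4 (0.17 log units; within the scatter). For compound 4 the estimate in this assay is 2500 nM, with a range from 700 nM to 9000 nM.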

Compound 4, half-maximal effective concentration: 3400 nM
Beside the measured number, compound 4's estimate is 1.4-fold (0.13 log units) below it; the range from low to high includes it.
By their numbers in this assay, from the lowest: compounds 3, 4 and 1 (each within the scatter of the next, the first and the last beyond it); then compound 2.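

Among the compounds shown here, on this carbonyl carbon, furan-2-yl in place of methyl gives a 2.0-fold higher number from compound 3 to compound 4 (0.30 log units; within the scatter) in this assay and so offers the first direct reading of this change. Going from one heavy atom to five, with an added aromatic ring, does not move the number beyond the scatter. No measurement shown explains this result.

From the compounds shown here alone, whether an amine, a carboxylic acid or a longer chain on this carbonyl carbon would behave alike remains open. So does whether the furan oxygen matters, which a thiophene ring could test.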